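This account rests on a few compounds, and the source may have more. Where it says the series, first, only, none or still open, it means among the compounds named here.

Working notes on the series. All three measured compounds share one core. Compound 1 `O=C(Nc1cccc(Oc2ccccc2)c1)C1CCCN(C(=O)c2cccc(-c3ccco3)c2)C1` is tested in an ADME assay on PC-3 cells (Homo sapiens) for cytotoxicity, read by WST assay, tested at 100 uM (a higher number here means more inhibition at the concentration tested (going by the name of the read-out), a lower number less inhibition), and gives 0%. In this assay compound 2 `CS(=O)(=O)Nc1cccc(C(=O)N2CCCC(C(=O)Nc3ccc(Cl)cc3)C2)c1` gives 3%, and compound 3 `CCc1cccc(NC(=O)C2CCCN(C(=O)c3cc(C(F)(F)F)cc(C(F)(F)F)c3)C2)c1` gives 0%. The number for compound 2 lies within the scatter of the number for compound 1 and within the scatter of the number for compound 3, so the three compounds cannot be told apart on these readings; the whole set sits close to zero inhibition at the concentration tested.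

Compound 4 `C=Cc1cccc(C(=O)N2CCCC(C(=O)Nc3ccc(Cl)cc3)C2)c1` is not yet measured. It differs from compound 2 in one place: vinyl in place of methanesulfonamido on an aromatic carbon. Among the measured compounds shown here, with no step between measured compounds to draw on, and all three numbers lying together, no step beyond the scatter is expected for this change in this assay in either direction. Compound 4 is expected to give about 2% in this assay, with a range from -8% to 12%. The step that this estimate means, a number 1 percentage points lower from compound 2 to compound 4 (within the scatter), is expected to stay within the scatter.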

Compound 4, a percentage reported as inhibition, at one concentration (the size of the read-out at that concentration, not a potency): 0%
Compound 4: the middle estimate sits 2 percentage points above what was measured; low and high end bracket the measured number.
By their numbers in this assay, from the lowest: compounds 1, 3, 4 and 2 (each within the scatter of the next).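

Among the compounds shown here, this is the first step that can be read at a single position: in this assay the change gives a number 3 percentage points lower from compound 2 to compound 4 (within the scatter) on an aromatic carbon of the six-membered ring, meta to a large group. The hydrogen-bond donor and acceptors of methanesulfonamido leave with this exchange, and vinyl brings none, yet the two compounds cannot be told apart on these readings. No measurement on hand explains why the two readings lie together.

For the compounds shown here, with both readings close to zero inhibition, this pair shows only that the exchange gives no readable step, and nothing about this position at readings further from zero. On these data alone, whether an amine or a carboxylic acid on this aromatic carbon would give a step beyond the scatter remains open.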